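Cyclohexyl to Cyclopropyl at the Leucine-Like Side Chain

The source may hold more compounds than are shown below. What is called first, only, known or untested is meant among the compounds shown, and "the series" means these compounds.

Measured so far in an ADME assay on Huh-7 cells (Homo sapiens) for cytotoxicity, with a stated time of 2 days; on this read-out higher numbers stand for lower toxicity in this test and lower numbers for higher toxicity in this test:
compound 1 `CC(C)C[C@H](NC(=O)/C=C/c1ccccc1)C(=O)N[C@@H](C[C@@H]1CCNC1=O)C(=O)C(=O)NCc1ccccc1` gives > 188000 nM; this figure is a limit of the test, not a number.
compound 2 `O=C(/C=C/c1ccccc1)N[C@@H](CC1CCCCC1)C(=O)N[C@@H](C[C@@H]1CCNC1=O)C(=O)C(=O)NCc1ccccc1` gives 43000 nM.

Within the data shown here, compound 2 holds the only actual number in this assay; the other value is a limit (the limit of > 188000 nM in this assay, at which 1 of the 2 values shown sits). Compound 3 `O=C(/C=C/c1ccccc1)N[C@@H](CC1CC1)C(=O)N[C@@H](C[C@@H]1CCNC1=O)C(=O)C(=O)NCc1ccccc1` differs from compound 2 by cyclopropyl in place of cyclohexyl on a saturated chain carbon, two bonds along the chain from an amide-type nitrogen and a carbonyl carbon. Among the measured compounds shown here, the one measured step, an at least 4.3-fold lower number from compound 1 to compound 2 (0.64 log units; beyond the scatter), went the other way in size of the group. Compound 3 is therefore expected to move back toward compound 1, with a 2.8-fold higher number from compound 2 to compound 3 (0.45 log units; beyond the scatter), and its estimated value is 120000 nM, in the range 45000 nM to 250000 nM.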

Compound 3, half-maximal cytotoxic concentration: > 189000 nM
Compound 3: a limit, no number (the forecaster's own chance of this, stated with the estimate: 40%); middle value at least 1.5-fold (0.19 log units) away from the limit.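

Putting cyclopropyl in place of cyclohexyl on this saturated chain carbon gives, in this assay, an at least 4.3-fold higher number from compound 2 to compound 3 (0.64 log units; beyond the scatter). Compound 3 gives a limit of the test and not a number: the limit of > 189000 nM in this assay, at which 1 of the 3 values shown sits. Of the three groups shown here, only the cyclohexyl of compound 2 gives an actual number, and the step between compound 1 and compound 3 cannot be read, as both values are limits.

On these data alone, what numbers lie behind those two limits stays open. So does whether a cyclopentyl or phenyl group at this position would also give an actual number.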